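Swapping One Six-Membered Heteroaromatic Ring for Another

The compounds below may be only part of what the source reports. "The series", "measured", "known", "first", "only" and "open" are said of these compounds alone.

Measured so far in an ADME assay on WI-38 cells (Homo sapiens) for inhibition, read by MTT assay, with a stated time of 72 h; a lower number here means a stronger inhibitor, a higher number a weaker inhibitor:
Compound 1, `O=C1O/C(=C\Cn2ncc(=O)[nH]c2=O)C(OCc2ccccc2)=C1OCc1ccccc1`, gives 24600 nM.
Compound 2, `Nc1ncn(C/C=C2\OC(=O)C(OCc3ccccc3)=C2OCc2ccccc2)c(=O)n1`, gives 4670 nM.
Compound 3, `NC1(CCn2ncc(=O)[nH]c2=O)OC(=O)C(OCc2ccccc2)=C1OCc1ccccc1`, gives only a limit, > 100000 nM.

Of the two plain numbers, compound 2 stands lowest. Within the data shown here, the single measured step, a 5.3-fold lower number from compound 1 to compound 2 (0.72 log units; beyond the scatter), separates it from compound 1 by more than the usual scatter. Among the measured compounds shown here, compound 3 reports a limit rather than a number, (the limit of > 100000 nM in this assay, at which 1 of the 3 values shown sits), and so offers no step that can be weighed.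

Compound 4, `O=C1O/C(=C\Cn2c(=O)[nH]c(=O)[nH]c2=O)C(OCc2ccccc2)=C1OCc1ccccc1`, differs from compound 2 by a group of 9 heavy atoms (3 carbon, 3 nitrogen, 3 oxygen; one six-membered aromatic ring with 3 hetero atoms) in place of a group of 8 heavy atoms (3 carbon, 4 nitrogen, 1 oxygen; one six-membered aromatic ring with 3 hetero atoms), on a saturated chain carbon bound to a double-bonded chain carbon. The change sits at the same place that was altered between compound 1 and compound 2, and it is of the same kind: one six-membered aromatic ring with three hetero atoms is exchanged for another. That earlier exchange, a 5.3-fold lower number from compound 1 to compound 2 (0.72 log units; beyond the scatter), lowered the number when the ring gained nitrogen and lost oxygen. The ring entering compound 4 trades nitrogen for oxygen, the opposite direction, so a rise of modest size in this assay is expected, back toward compound 1. Compound 4 is therefore estimated at 25000 nM, with a range from 7000 nM to 90000 nM. The expected step is a 5.4-fold higher number from compound 2 to compound 4 (0.73 log units; beyond the scatter).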

Compound 4, half-maximal inhibitory concentration: 10 nM
Compound 4: the middle estimate sits 2500-fold (3.40 log units) above what was measured; the whole stated range lies above it.
By their numbers in this assay, from the lowest: compound 4; then compound 2; then compound 1. At a limit, above all of these: compound 3.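

In this assay, among these compounds, the ring at this place, on a saturated chain carbon bound to a double-bonded chain carbon, can move the number much further than the earlier compounds showed. The ring entering compound 4 gives the largest change so far (a 470-fold lower number from compound 2 to compound 4 (2.67 log units; beyond the scatter)), and the same holds against the ring of compound 1 (a 2500-fold lower number from compound 1 to compound 4 (3.39 log units; beyond the scatter)). The amount of ring oxygen does not put the numbers in order: compound 1 stands above compound 2, yet compound 4, with the most ring oxygen, stands lowest of the three.

Still open, as far as these compounds go, is whether an amine or a carboxylic acid in place of this ring, or a longer chain carrying it, would keep so low a number. Nothing measured here accounts for the size of this step.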